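A few compounds are considered here, and "the series" means these few. Any claim that something is new, unique, unknown or untested is made for them only; others in the source may bear on it.

Compound 1 `Cc1ccc(/C=C/C(=O)O/C(=N/C2CCCCC2)NC2CCCCC2)cc1` and compound 2 `O=C(/C=C/c1ccccc1)O/C(=N/C1CCCCC1)NC1CCCCC1` share one core, while compound 3 `COC(=O)[C@@H]1COC(/C=C/c2ccc(C)cc2)=N1` and compound 4 `COC(=O)[C@@H]1COC(/C=C/c2ccccc2)=N1` share another; the difference between the two cores is not broken down here. In an ADME assay on Vero cells (Chlorocebus sabaeus) for cytotoxicity, read by WST assay, tested at 100 ug/mL (on this read-out higher numbers stand for a weaker effect at the one concentration tested and lower numbers for a stronger effect), compound 1 gives 95.5%, and compound 2 gives 83.8%. The change from compound 1 to compound 2 is hydrogen in place of methyl on an aromatic carbon, and it made the step of a number 11.7 percentage points lower from compound 1 to compound 2 (beyond the scatter). In this assay compound 3 gives 17%, the lowest of the three numbers. Compound 4 differs from compound 3 by hydrogen in place of methyl on an aromatic carbon, which is the same change at the same place. For compound 4 a step of a number 5 percentage points lower from compound 3 to compound 4 (within the scatter) is expected in this assay, because compound 3 starts from 17%, leaving little room for a further fall, and because the earlier step of a number 11.7 percentage points lower from compound 1 to compound 2 (beyond the scatter) was modest. The estimate for compound 4 is 12%, expected between 3% and 30%.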

Compound 4, a percentage reported as activity, at one concentration (the size of the read-out at that concentration, not a potency): 12.4%
Compound 4: middle estimate off by 0.4 percentage points, on the low side, within the range that was stated.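

In this assay, putting hydrogen in place of methyl on the aromatic carbon gives a number 4.6 percentage points lower from compound 3 to compound 4 (within the scatter). Set beside the earlier step on the other core, the two steps do not differ by more than repeated measurements would: the same change on two cores in this assay, a number 11.7 percentage points lower (beyond the scatter) from compound 1 to compound 2 and a number 4.6 percentage points lower (within the scatter) from compound 3 to compound 4, 7.1 percentage points apart, within the scatter of two such steps This shows no measurable difference in how the change carries between these two cores, but with only one pair of compounds on each core, it does not show that the two steps are truly equal or that the same would hold on a third core.

The compounds shown leave open what a methoxy group, a chlorine atom or an amine would do at that place on the ring. Only methyl and hydrogen appear there, on either core.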